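Compound 4 after three readings at the assay limit

The compounds below may be only part of what the source reports. "The series", "measured", "known", "first", "only" and "open" are said of these compounds alone.

Measured in a functional assay on MCF7 cells (Homo sapiens) for cytotoxicity, read by MTT assay, with a stated time of 48 h; a lower number here means a stronger inhibitor, a higher number a weaker inhibitor:
- compound 1 `Fc1cccc(-c2nc(Nc3ccccc3F)c3cc(F)ccc3n2)c1`: > 50000 nM
- compound 2 `Fc1cccc(-c2nc(Nc3ccccc3Cl)c3cc(F)ccc3n2)c1`: > 50000 nM
- compound 3 `Oc1ccccc1Nc1nc(-c2cccc(F)c2)nc2ccc(F)cc12`: > 50000 nM

Each of these entries is a limit of the assay and not a number. Compound 3 stands at its limit of > 50000 nM. The other two compounds share that position: the limit of > 50000 nM in this assay, at which 3 of the 3 values shown sit.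

Compound 4 `Cc1ccc(Nc2nc(-c3cccc(F)c3)nc3ccc(F)cc23)cc1` keeps the shared core and differs from compound 3 in one place, with 4-methylphenyl in place of 2-hydroxyphenyl on a nitrogen on an aromatic ring. The closest evidence comes from three measured changes to a single group on that phenyl ring: a step that the two limits leave unreadable from compound 1 to compound 2, a step that the two limits leave unreadable from compound 1 to compound 3 and a step that the two limits leave unreadable from compound 2 to compound 3. Within the data shown here, both ends of each step are limits, so none has a readable size, and no measured compound carries 4-methylphenyl.

Compound 4 is therefore expected to stay close to compound 3 at > 50000 nM, and it may well be reported as a limit again. The expected change, a number no higher from compound 3 to compound 4 (the limit leaves the size open), has no firm direction. For compound 4 the estimated value is 50000 nM, with an expected range from 12000 nM to 100000 nM.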

Compound 4, half-maximal inhibitory concentration: > 50000 nM
Compound 4 was reported as a limit; the forecaster's own chance of this, stated with the estimate: 65%; the middle value lies on the limit itself.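

Compound 4, like compound 1, compound 2 and compound 3, is reported only as a limit and not a number, so no step among these compounds can be read: the limit of > 50000 nM in this assay, at which 4 of the 4 values shown sit.

The compounds shown leave open whether any of these groups on the nitrogen makes one compound stronger or weaker than another in this assay.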